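This account rests on a few compounds, and the source may have more. Where it says the series, first, only, none or still open, it means among the compounds named here.

Of the compounds shown here, three have so far been measured in an assay on HEK293 cells for agonist activity at transient receptor potential cation channel subfamily M member 8 (Homo sapiens), read by fluorescence and calcium flux, with a stated time of 15 min; on this read-out lower numbers stand for an effect already at smaller amounts and higher numbers for an effect only at larger amounts of compound. Compound 1 `CCN(Cc1cccs1)C(=O)COc1ccc(C(C)C)cc1` gives 397 nM in this assay, and compound 3 `CCN(Cc1cccs1)C(=O)c1cc2cc(OC)ccc2o1` gives 80 nM. Compound 2 `Cc1ccc(OCC(=O)N(Cc2cccs2)c2ccn(C)n2)cc1` gives 855 nM, the highest of the three numbers; its gap to compound 1 and its larger gap to compound 3 both lie beyond the usual scatter of repeated measurements, so compound 2 acts only at larger amounts than either of the other two.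

Compound 4 `Cc1ccc(OCC(=O)N(Cc2cccs2)c2nccn2C)cc1` has not yet been measured. It keeps every atom of compound 2 but joins them differently.

1-methyl-1H-imidazol-2-yl in place of 1-methyl-1H-pyrazol-3-yl on an amide-type nitrogen

Among the compounds with values here, no pair of measured compounds differs in only one place, so nothing measured so far shows what such a rearrangement does in this assay. The change keeps the same count of atoms and of hydrogen-bond acceptors, and a step no larger than the usual scatter is expected, with no firm direction. Compound 4 is therefore estimated at 1000 nM, within a range from 300 nM to 3500 nM. The step of a 1.2-fold higher number from compound 2 to compound 4 (0.07 log units; within the scatter) is expected to be small.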

Compound 4, half-maximal effective concentration: 1790 nM
Compound 4: the middle estimate sits 1.8-fold (0.25 log units) below what was measured, and the stated range covers the measured number.
By their numbers in this assay, from the lowest: compound 3; then compound 1; then compound 2; then compound 4.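

In this assay, within the data shown here, the change of 1-methyl-1H-pyrazol-3-yl to 1-methyl-1H-imidazol-2-yl on the amide-type nitrogen gives a 2.1-fold higher number from compound 2 to compound 4 (0.32 log units; beyond the scatter) and is the first step here that can be read in one place. The two groups match in heavy atoms, ring size, hydrogen-bond donors and acceptors and charge, so at this position the way the same atoms are joined can shift the number, even though those counts stay the same. No information on hand says what lies behind this modest step, so its cause remains unknown. Going by these compounds, how a pyridine ring or a carboxylic acid would read on this same nitrogen remains open. Also open, on these data alone, is whether the same swap would give a similar step on the core of compound 3.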